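The source may hold more compounds than are shown below. What is called first, only, known or untested is meant among the compounds shown, and "the series" means these compounds.

In an ADME assay on microsomes from liver (Homo sapiens) for metabolic stability (a higher number here means that the compound lasts longer, a lower number that the compound disappears faster), compound 1 `CCn1ncc2c(F)cc(-c3ccc(C(CC)(CC)c4nnc(C)[nH]4)c(=O)[nH]3)cc21` gives > 3 h, which is a limit of the assay and not a number. Among the compounds with values here, compound 2 `CCn1ncc2c(F)cc(-c3ccc(C(CC)(CC)c4nncn4C)c(=O)[nH]3)cc21` gives 2.67 h, the only actual number available so far. Compound 3 `CCn1ncc2c(F)cc(-c3ccc(C(CC)(CC)c4ncn(C)n4)c(=O)[nH]3)cc21` shares its atoms with compound 2 but joins them differently, carrying 1-methyl-1H-1,2,4-triazol-3-yl in place of 4-methyl-4H-1,2,4-triazol-3-yl on a saturated chain carbon bound to an aromatic carbon and two saturated chain carbons. Within the data shown here, one measured step bears on this change, since it also exchanges one methyl-bearing triazole for another at the same place, with 4-methyl-4H-1,2,4-triazol-3-yl replacing 5-methyl-4H-1,2,4-triazol-3-yl. That step is an at least 1.1-fold lower number from compound 1 to compound 2 (0.05 log units; that floor lies within the scatter), so it gives only a floor and not a full size. With this single step as a guide, no change beyond the scatter is expected in this assay, and the expectation starts from compound 2 at 2.67 h. The estimated change is a 1.2-fold lower number from compound 2 to compound 3 (0.06 log units; within the scatter). For compound 3, the estimated half-life is 2.3 h, with an expected range from 1.2 h to 4 h.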

Compound 3, half-life: > 3 h
Compound 3 ended at the assay's limit; the forecaster's own chance of this, stated with the estimate: 25%; middle value at least 1.3-fold (0.11 log units) from the limit.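

In this assay compound 3 gives > 3 h, which is a limit of the assay and not a number, so a third methyl-bearing triazole on this saturated chain carbon also reaches that limit. With 1-methyl-1H-1,2,4-triazol-3-yl in place of 4-methyl-4H-1,2,4-triazol-3-yl, the change amounts to an at least 1.1-fold higher number from compound 2 to compound 3 (0.05 log units; that floor lies within the scatter), which shows no loss of half-life but does not establish a real gain. The step between the two limit values cannot be read, and the 5-methyl-4H-1,2,4-triazol-3-yl and 1-methyl-1H-1,2,4-triazol-3-yl groups cannot be ranked against each other because the read-out stops at a ceiling: the limit of > 3 h in this assay, at which 2 of the 3 values shown sit.

Going by these compounds, how far the half-lives of the compounds at this limit actually extend remains open, as does whether the three triazoles truly differ in this assay. Also open, on these data alone, is whether this tolerance at the position extends beyond triazoles, for instance to a carboxylic acid or a nitrile on the same saturated chain carbon.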